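A few compounds are considered here, and "the series" means these few. Any claim that something is new, unique, unknown or untested is made for them only; others in the source may bear on it.

Measured compounds:
compound 1 `O=C(NC1CCN(Cc2ccccc2)CC1)c1coc2ccccc2c1=O`, 17700 nM
compound 2 `COc1ccc2occ(C(=O)NC3CCN(Cc4ccccc4)CC3)c(=O)c2c1`, 46300 nM
compound 3 `O=C(NCCC1CCN(Cc2ccccc2)CC1)c1coc2ccccc2c1=O`, 35300 nM

All three were tested in an assay on isolated protein for inhibition of Amine oxidase [flavin-containing] B (Homo sapiens), read by fluorescence and Amplex Red, with stated times of 15 min and 20 min; a higher number here means a weaker inhibitor, a lower number a stronger inhibitor. Compound 1 and compound 2 share a core and differ only by methoxy in place of hydrogen on an aromatic carbon; this change gave a 2.6-fold higher number from compound 1 to compound 2 (0.42 log units; beyond the scatter). Compound 3 carries a different core, and the difference between the two cores is not broken down here; its value and that of compound 1 lie within the scatter of each other, as do those of compound 3 and compound 2.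

Compound 4 `COc1ccc2c(=O)c(C(=O)NCCC3CCN(Cc4ccccc4)CC3)coc2c1` has not yet been measured. It differs from compound 3 by methoxy in place of hydrogen on an aromatic carbon, the same change as that from compound 1 to compound 2, made at the same kind of place on the aromatic ring. Resting on the step of a 2.6-fold higher number from compound 1 to compound 2 (0.42 log units; beyond the scatter), a similar weakening is expected for compound 4 in this assay, so the estimated step is a 2.4-fold higher number from compound 3 to compound 4 (0.38 log units; beyond the scatter). Compound 4 is therefore expected to give about 85000 nM, with a likely range from 40000 nM to 180000 nM.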

Compound 4, half-maximal inhibitory concentration: 30900 nM
Compound 4: middle estimate off by 2.8-fold (0.44 log units), on the high side; the measured number lies below the stated range.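

Carried to the core of compound 3, methoxy in place of hydrogen on an aromatic carbon gave a 1.1-fold lower number from compound 3 to compound 4 (0.06 log units; within the scatter) in this assay, a step that stays within the scatter. The weakening seen with the same change on the core of compound 1 therefore did not carry over, and the two steps differ: the same change on two cores in this assay, a 2.6-fold higher number (0.42 log units; beyond the scatter) from compound 1 to compound 2 and a 1.1-fold lower number (0.06 log units; within the scatter) from compound 3 to compound 4, 3.0-fold (0.48 log units) apart, beyond the scatter of two such steps. This shows that, for these two pairs, the size of the step depends on the core it is made on, so a step read on one core was no safe guide to the other; it does not show which difference between the cores is responsible, and two pairs give no rule for any further core in the series.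

The compounds shown leave open how a group other than methoxy, such as a halogen, a hydroxyl or an amine, would behave on the same aromatic carbon of either core. They also leave open whether a longer chain on the amide would keep the step as it stands on compound 3 and compound 4.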